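A Ring Swap on the Double-Bonded Chain Carbon

The compounds below may be only part of what the source reports. "The series", "measured", "known", "first", "only" and "open" are said of these compounds alone.

Measured in a functional assay on MCF7 cells (Homo sapiens) for cytotoxicity, read by CellTiter-Glo, with a stated time of 5 days; on this read-out lower numbers stand for stronger inhibition and higher numbers for weaker inhibition:
- compound 1 `CC/C(=C(/c1ccc(/C=C/C(=O)O)cc1)c1ccc2[nH]ncc2c1)c1ccccc1OC`: 25 nM
- compound 2 `CC/C(=C(/c1ccc(/C=C/C(=O)O)cc1)c1ccc2[nH]ncc2c1)c1ccc(C#N)cc1C`: 5 nM

Of these two, compound 2 has the lower number, at 5 nM. Compound 3 `CC/C(=C(/c1ccc(/C=C/C(=O)O)cc1)c1ccc2[nH]ncc2c1)c1cscc1C` has 4-methylthiophen-3-yl in place of 4-cyano-2-methylphenyl on the same carbon: 4-methylthiophen-3-yl in place of 4-cyano-2-methylphenyl on a double-bonded chain carbon bound to a double-bonded chain carbon and a saturated chain carbon. One measured step changes this same place, and it is modest and beyond the scatter: a 5.0-fold lower number from compound 1 to compound 2 (0.70 log units; beyond the scatter). Going by the values given here, no compound with this new group has been measured, so the direction is uncertain. Starting from the lower of the two numbers, a modest rise is expected, estimated as a 2.4-fold higher number from compound 2 to compound 3 (0.38 log units; beyond the scatter). For compound 3 the estimated value is 12 nM, with an expected range from 4 nM to 35 nM.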

Compound 3, half-maximal inhibitory concentration: 2 nM
Compound 3: middle estimate off by 6.0-fold (0.78 log units), on the high side; the whole stated range lies above it.
By their numbers in this assay, from the lowest: compound 3; then compound 2; then compound 1.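

In this assay, 4-methylthiophen-3-yl gives a 2.5-fold lower number from compound 2 to compound 3 (0.40 log units; beyond the scatter) and a 13-fold lower number from compound 1 to compound 3 (1.10 log units; beyond the scatter) on this double-bonded chain carbon. Among these compounds, then, neither a six-membered aromatic ring of carbon only nor the nitrile is needed here, and compound 3, whose group has fewer heavy atoms, has the lowest number of the three. No measurement at hand gives a reason for this drop.

Going by these compounds, whether the methyl group of 4-methylthiophen-3-yl is needed remains open. So does how a furan ring or a thiazole ring would fare in the same place.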